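The source may report more compounds than this note shows. Statements on the series, on what has been measured and on what is new or still open speak of the compounds shown alone.

Compound 1, `CCO/C(O)=C1\C(COCCN2CC(=O)N(C)C2=O)=NC(C)=C(C(=O)OC)C1c1cccc(Cl)c1Cl`, was tested in a functional assay (aorta) with Rattus norvegicus as the target (a lower number here means a stronger inhibitor, a higher number a weaker inhibitor), and there compound 1 gives 5.01 nM. Compound 2, `CCO/C(O)=C1\C(COCCn2ccnc2C)=NC(C)=C(C(=O)OC)C1c1ccccc1Cl`, gives 2.51 nM in this assay, and the two numbers lie within the usual scatter of each other, so neither stands apart. Compound 3, `CCO/C(O)=C1\C(COCCN2CC(=O)NC2=O)=NC(C)=C(C(=O)OC)C1c1cccc(Cl)c1Cl`, has not yet been measured. It differs from compound 1 in one place, (hydrogen in place of methyl on an amide-type nitrogen in a ring), hydrogen in place of methyl on an amide-type nitrogen in a ring. Going by the values given here, no measured pair shows such a change here, so the expected step of a 1.0-fold lower number from compound 1 to compound 3 (0.00 log units; within the scatter) is small, not beyond the scatter in either direction. Compound 3 is therefore expected to give about 5 nM, between 1.5 nM and 16 nM.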

Compound 3, half-maximal inhibitory concentration: 3.16 nM
Compound 3: the middle estimate sits 1.6-fold (0.20 log units) above what was measured; low and high end bracket the measured number.
By their numbers in this assay, from the lowest: compounds 2, 3 and 1 (each within the scatter of the next).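

Going by these compounds alone, replacing the methyl with hydrogen on the amide-type nitrogen in the ring gives a 1.6-fold lower number from compound 1 to compound 3 (0.20 log units; within the scatter) in this assay and is the first single-place change that can be read here. At this position, then, the methyl group can give way to hydrogen without the number moving beyond the scatter. Nothing given here explains this result.

The compounds shown leave open how an ethyl group, a benzyl group or a chain ending in an amine or a carboxylic acid on this nitrogen would read in this assay and whether the number would stay within the scatter.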